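A few compounds are considered here, and "the series" means these few. Any claim that something is new, unique, unknown or untested is made for them only; others in the source may bear on it.

Measured in a functional assay on A549 cells (Homo sapiens) for antiproliferative activity, read by MTT assay; a higher number here means a weaker inhibitor, a lower number a stronger inhibitor:
- compound 1 `O=C1NC(c2ccccc2)CN1S(=O)(=O)c1ccc2c(c1)CCCN2`: > 20000 nM
- compound 2 `COC(=O)N1CCCc2cc(S(=O)(=O)N3CC(c4ccccc4)NC3=O)ccc21`: 1150 nM

The entry for compound 1 is a limit of the assay, not a number. Going by the values given here, that leaves compound 2, at 1150 nM, as the only true number in this assay so far.

The next compound, compound 3 `CCOC(=O)N1CCCc2cc(S(=O)(=O)N3CC(c4ccccc4)NC3=O)ccc21`, differs from compound 2 in one place: methyl in place of hydrogen on a saturated chain carbon bound to an oxygen next to a carbonyl group. Methoxycarbonyl thus becomes ethoxycarbonyl, while the rest of the molecule stays the same.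

Among the compounds with values here, only one measured step bears on this. Bringing in methoxycarbonyl gave an at least 17-fold lower number from compound 1 to compound 2 (1.24 log units; beyond the scatter). That large step installed the whole group, whereas compound 3 keeps the group and only extends it by a methyl. Within the data shown here, the earlier step therefore shows that this spot matters, but it does not measure a change this small, and no methyl-for-hydrogen step has been measured here. The expected result in this assay is a 1.0-fold lower number from compound 2 to compound 3 (0.02 log units; within the scatter), with no shift beyond the scatter in either direction.

For compound 3 the estimated value is 1100 nM, with an expected range of 450 nM to 2800 nM.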

Compound 3, half-maximal inhibitory concentration: 344 nM
Compound 3: the middle estimate sits 3.2-fold (0.50 log units) above what was measured; measured number outside the range, below it.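

The earlier compounds shown here showed only that methoxycarbonyl on this nitrogen matters in this assay. Compound 3 adds that the outer end of the group counts too: one methyl, turning methoxycarbonyl into ethoxycarbonyl, gives a 3.3-fold lower number from compound 2 to compound 3 (0.52 log units; beyond the scatter), so this site responds to a small extension and not only to the presence of the whole group. Against the plain hydrogen, ethoxycarbonyl gives an at least 58-fold lower number from compound 1 to compound 3 (1.76 log units; beyond the scatter), and the entry for compound 1 is a limit of the assay, not a number, so this step is only a bound because of it: the limit of > 20000 nM in this assay, at which 1 of the 3 values shown sits.

On these data alone, two chain lengths do not make a trend, so it stays open whether a longer chain, as in propoxycarbonyl, or a branched one, as in isopropoxycarbonyl, would lower the number further or reverse the change. The compounds shown also do not tell how an acetyl group, which lacks the oxygen of these groups, or a benzyloxycarbonyl group would compare on this nitrogen, and they offer no explanation for the effect of the added methyl.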